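The source may report more compounds than this note shows. Statements on the series, on what has been measured and on what is new or still open speak of the compounds shown alone.

Measured in a functional assay on PC-3 cells (Homo sapiens) for cytotoxicity, read by MTT assay, with a stated time of 72 h; a higher number here means a weaker inhibitor, a lower number a stronger inhibitor:
- compound 1 `COc1cc(/C=C/C=O)cc(OC)c1OC/C=C(\C)CCC=C(C)C`: 39000 nM
- compound 2 `C=C(C)CCOc1ccc(C(=O)O)cc1OC`: > 100000 nM (a limit of the assay)
- compound 3 `COc1cc(/C=C/C=O)ccc1OC/C=C(\C)CCC=C(C)C`: 24000 nM

Within the data shown here, compound 3 and compound 1 give the only two numbers in the set, and they lie within the scatter of each other. Compound 4 `COc1cc(/C=C/CO)ccc1OC/C=C(\C)CCC=C(C)C` carries hydroxymethyl in place of formyl on a double-bonded chain carbon bound to a double-bonded chain carbon. Among the measured compounds shown here, the one measured step, a 1.6-fold lower number from compound 1 to compound 3 (0.21 log units; within the scatter), is hydrogen in place of methoxy on an aromatic carbon, a different change, so it bears on this one only loosely. For the measured compounds named here, compound 2, the only measured compound without formyl, stands at the limit > 100000 nM. It differs in much else, so it is a weak hint of direction. The expected change in this assay is a 1.9-fold higher number from compound 3 to compound 4 (0.27 log units; within the scatter), a small move toward a weaker inhibitor. For compound 4 the estimated value is 45000 nM, with an expected range of 18000 nM to 100000 nM.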

Compound 4, half-maximal inhibitory concentration: 21000 nM
Beside the measured number, compound 4's estimate is 2.1-fold (0.33 log units) above it, and the stated range covers the measured number.
By their numbers in this assay, from the lowest: compounds 4, 3 and 1 (each within the scatter of the next). At a limit, above all of these: compound 2.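

In this assay, the place on a double-bonded chain carbon bound to a double-bonded chain carbon takes hydroxymethyl in place of formyl with a 1.1-fold lower number from compound 3 to compound 4 (0.06 log units; within the scatter), so the two groups cannot be told apart here. Formyl is therefore not needed for compound 4 to give a number in the range of compound 3, and the hydrogen-bond donor that enters leaves no readable mark. No measured property shown accounts for this step.

From the compounds shown here alone, whether an amine or a carboxylic acid at this place would hold the number stays open. So does whether the same exchange behaves alike on the core of compound 1.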